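Swapping a Nitro for a Fluoro

A few compounds are considered here, and "the series" means these few. Any claim that something is new, unique, unknown or untested is made for them only; others in the source may bear on it.

In a functional assay on CCRF-CEM cells (Homo sapiens) for cytotoxicity, in the absence of a further agent (on this read-out higher numbers stand for weaker inhibition and lower numbers for stronger inhibition), compound 1 (`COC(=O)c1ccc(CN(CCCc2c(N)nc(N)nc2O)c2cc(F)cc(F)c2[N+](=O)[O-])cc1`) gives > 100000 nM as a limit of the assay and not a number. For the measured compounds named here, compound 2 (`COC(=O)c1ccc(CN(CCCc2c(N)nc(N)nc2O)c2cc(F)c([N+](=O)[O-])cc2[N+](=O)[O-])cc1`) gives 2500 nM as the only true number so far. Compound 3 (`COC(=O)c1ccc(CN(CCCc2c(N)nc(N)nc2O)c2cc(F)c(F)cc2[N+](=O)[O-])cc1`) is unmeasured and differs from compound 2 by fluoro in place of nitro on an aromatic carbon with the rest unchanged. Going by the values given here, no measured pair shows this swap. Weaker inhibition in this assay is expected, an expectation leaning only on compound 1 with its limit of > 100000 nM as the sole other result. The expected change is (a 10-fold higher number from compound 2 to compound 3 (1.00 log units; beyond the scatter)) towards weaker inhibition. Compound 3 is estimated at 25000 nM within a range from 5000 nM to 100000 nM for now.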

Compound 3, half-maximal inhibitory concentration: 59000 nM
Compound 3: middle estimate off by 2.4-fold (0.37 log units), on the low side; the range from low to high includes it.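

Fluoro in place of nitro, on the carbon para to a large group, gives a 24-fold higher number from compound 2 to compound 3 (1.37 log units; beyond the scatter) in this assay, so inhibition at this position depends strongly on which of these two groups it carries. Compound 1 is recorded only as a limit of the assay, so moving the fluoro group gives only an at least 1.6-fold lower number from compound 1 to compound 3 (0.22 log units; that floor lies within the scatter), and the two arrangements cannot be ordered. That step stays open-ended because one end of it is a limit: the limit of > 100000 nM in this assay, at which 1 of the 3 values shown sits.

The compounds shown give no cause for the large step. From the compounds shown here alone, whether a nitrile or a trifluoromethyl group here would behave like nitro or like fluoro remains open.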